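A few compounds are considered here, and "the series" means these few. Any claim that something is new, unique, unknown or untested is made for them only; others in the source may bear on it.

Compound 1 `COc1cccc(OC)c1OCCNCCOc1ccccc1OCc1cccc(Cl)c1` gives 20400 nM in a functional assay on PC-3 cells (Homo sapiens) for cytotoxicity, read by sulforhodamine B assay (a lower number here means a stronger inhibitor of growth, a higher number a weaker inhibitor of growth), the highest of the two numbers measured here. Compound 2 `COc1cccc(OC)c1OCCNCCOc1ccccc1OCc1ccc(Cl)cc1` gives 14500 nM in this assay, and the step of a 1.4-fold lower number from compound 1 to compound 2 (0.15 log units; within the scatter) stays within the scatter. Compound 3 `COc1cccc(OC)c1OCCNCCOc1ccccc1OCc1ccccc1C` differs from compound 1 by 2-methylphenyl in place of 3-chlorophenyl on a saturated chain carbon bound to an oxygen on an aromatic ring. Among the compounds with values here, only that one measured step, exchanging one chlorophenyl for another, bears on this change, and it was small, so no step beyond the scatter is expected in this assay: a 1.0-fold lower number from compound 1 to compound 3 (0.01 log units; within the scatter). Compound 3 is therefore estimated at 20000 nM, within the range 8000 nM to 50000 nM.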

Compound 3, concentration for total growth inhibition: 33900 nM
Compound 3: middle estimate off by 1.7-fold (0.23 log units), on the low side; the range from low to high includes it.
By their numbers in this assay, from the lowest: compounds 2, 1 and 3 (each within the scatter of the next, the first and the last beyond it).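

In this assay, within the data shown here, 2-methylphenyl in place of 3-chlorophenyl gives a 1.7-fold higher number from compound 1 to compound 3 (0.22 log units; within the scatter) and stays within the scatter, whereas 2-methylphenyl in place of 4-chlorophenyl gives a 2.3-fold higher number from compound 2 to compound 3 (0.37 log units; beyond the scatter) and is the first step here beyond the scatter, though only a modest one. Nothing available explains this gap between compound 2 and compound 3. The compounds shown change both the group on the ring and its place together, so 2-chlorophenyl or 4-methylphenyl would be needed to separate the two. From the compounds shown here alone, how an amine or a carboxylic acid on this ring would fare also remains open.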